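The source may report more compounds than this note shows. Statements on the series, on what has been measured and on what is new or still open speak of the compounds shown alone.

Compound 1 `O=C(C1CCC(F)(F)CC1)N1CC(c2nc(-c3cccc(Cl)c3)no2)C1` gives > 10000 nM in an assay on HEK293 cells for negative allosteric modulation of metabotropic glutamate receptor 5 (Homo sapiens), read by FLIPR (on this read-out higher numbers stand for weaker inhibition and lower numbers for stronger inhibition), a limit of the assay.
Compound 2 `O=C(c1ccc(F)c(F)c1)N1CC(c2nc(-c3cccc(F)c3)no2)C1` gives > 10000 nM in this assay, likewise a limit.
Compound 3 `COC1CCN(C(=O)N2CC(c3nc(-c4cccc(Cl)c4)no3)C2)CC1` gives > 10000 nM in this assay, again a limit.

Compound 3 thus stands only at a limit, as do both other measured compounds, all three sitting at the limit of > 10000 nM in this assay, at which 3 of the 3 values shown sit. Going by the values given here, the single measured step, a step that the two limits leave unreadable from compound 1 to compound 3, runs between two limits and yields no readable size. Compound 4 `O=C(c1cccc(F)c1)N1CC(c2nc(-c3cccc(Cl)c3)no2)C1` differs from compound 3 by 3-fluorophenyl in place of 4-methoxypiperidin-1-yl on a carbonyl carbon. Among the compounds with values here, no measured step bears directly on this change. Compound 2, which also carries an aromatic ring on the carbonyl carbon, sits at the limit. Compound 4 is therefore expected to remain at or near the limit, with an estimated step of a number no higher from compound 3 to compound 4 (the limit leaves the size open). Compound 4 is estimated at 10000 nM, within a range from 2500 nM to 40000 nM.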

Compound 4, half-maximal inhibitory concentration: 780 nM
Estimate against measurement, compound 4: 13-fold (1.11 log units) above; measured number outside the range, below it.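

In this assay, 3-fluorophenyl on the carbonyl carbon gives an at least 12-fold lower number from compound 3 to compound 4 (1.10 log units; beyond the scatter), and the same group gives an at least 12-fold lower number from compound 1 to compound 4 (1.10 log units; beyond the scatter). The group on this carbonyl carbon can therefore bring a compound off the limit, which the earlier compounds could not show, since each stands only at a limit: the limit of > 10000 nM in this assay, at which 3 of the 4 values shown sit.

As far as these compounds go, whether the ring fluorine is needed remains open, as does the outcome with a plain phenyl or a pyridine ring on the same carbonyl carbon. Compound 2 differs from compound 4 in more than one place, so it cannot settle this.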